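Biguanide series on HCT-116: heptyl to cyclopentyl

The compounds below may be only part of what the source reports. "The series", "measured", "known", "first", "only" and "open" are said of these compounds alone.

Measured so far:
compound 1 `CCCCCCCNC(=N)NC(=N)Nc1ccc(F)c(F)c1` — 1800 nM
compound 2 `CC(C)CNC(=N)NC(=N)Nc1ccc(F)cc1F` — 21100 nM

In a functional assay on HCT-116 cells (Homo sapiens) for antiproliferative activity, read by MTT assay, with a stated time of 72 h (on this read-out higher numbers stand for weaker inhibition and lower numbers for stronger inhibition), compound 1 gives 1800 nM, the lower of the two numbers; compound 2 gives 21100 nM, a higher number that lies beyond the usual scatter. Compound 3 `N=C(NC(=N)NC1CCCC1)Nc1ccc(F)c(F)c1` has not yet been measured in this assay. It differs from compound 1 in one place: cyclopentyl in place of heptyl on an amine nitrogen. Among the measured compounds shown here, no pair of measured compounds differing in a single place exists, so the size of this change in this assay is open. Compound 2 shows a higher number than compound 1, but its structure differs in more than one place, so it does not isolate this change. Compound 3 is expected to fall near 5000 nM, within 1800 nM to 15000 nM. The expected step of a 2.8-fold higher number from compound 1 to compound 3 (0.44 log units; beyond the scatter) is modest, toward weaker inhibition, with an unchanged result also plausible.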

Compound 3, half-maximal inhibitory concentration: 16800 nM
The estimate for compound 3 lay 3.4-fold (0.53 log units) below the measured number; measured number above the stated range.
By their numbers in this assay, from the lowest: compound 1; then compounds 3 and 2 (each within the scatter of the next).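

In this assay the first step read at a single place puts a size on this change: a 9.3-fold higher number from compound 1 to compound 3 (0.97 log units; beyond the scatter) toward weaker inhibition. The group on this amine nitrogen therefore matters in this assay, since cyclopentyl in place of heptyl, with the rest of compound 1 unchanged, moves the number beyond the usual scatter. No measurement shown gives a reason for this step.

The change replaces an open chain with a ring and also shortens the carbon count, so these two differences remain unseparated; a pentyl chain on the same nitrogen would tell them apart. Also open, from the compounds shown here alone, is how a chain longer than heptyl or a cyclohexyl ring would read at this position.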